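The source may hold more compounds than are shown below. What is called first, only, known or untested is meant among the compounds shown, and "the series" means these compounds.

Working notes on the series.

Compound 1 `CC(C)n1ncc2c(C(=O)NC3CCCC3)cccc21` carries a cyclopentyl amide on the shared core. In a functional assay on PC-3 cells (Homo sapiens) for inhibition, read by MTT assay, with a stated time of 72 h (a higher number here means a weaker inhibitor, a lower number a stronger inhibitor), compound 1 gives 19400 nM. Compound 2 `CC(C)n1ncc2c(C(=O)NCc3cn(-c4cccc(F)c4)nn3)cccc21` carries the amide through a methylene onto a triazole that bears a 3-fluorophenyl, and in this assay compound 2 gives 36100 nM. The two numbers lie within the scatter of each other, so neither compound is told apart from the other; both are weak inhibitors on these cells.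

Compound 3 `CC(C)n1ncc2c(C(=O)NCc3cn(Cc4ccccc4)nn3)cccc21` is not yet measured. It differs from compound 2 by a single change: benzyl in place of 3-fluorophenyl on an aromatic nitrogen. Among the compounds with values here, no measured pair isolates this change, so nothing indicates its direction. With two weak numbers close together, the expectation for compound 3 in this assay is no step beyond the scatter, a 1.2-fold lower number from compound 2 to compound 3 (0.08 log units; within the scatter). Compound 3 is therefore estimated at 30000 nM, with a range from 12000 nM to 80000 nM.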

Compound 3, half-maximal inhibitory concentration: 4420 nM
Beside the measured number, compound 3's estimate is 6.8-fold (0.83 log units) above it; the measured number lies below the stated range.
By their numbers in this assay, from the lowest: compound 3; then compounds 1 and 2 (each within the scatter of the next).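

In this assay, within the data shown here, the group on the aromatic nitrogen of the five-membered ring is the first place where a single change moves the number beyond the scatter: benzyl in place of 3-fluorophenyl gives an 8.2-fold lower number from compound 2 to compound 3 (0.91 log units; beyond the scatter). The two groups have the same heavy-atom count and each holds one six-membered aromatic ring of carbon only, so this position responds to a change that leaves those counts untouched. No measurement on hand gives a reason for the step.

The swap removes the fluorine and also sets a carbon between the aromatic ring and the nitrogen, and the compounds shown do not separate these two differences. Also open, from the compounds shown here alone, are how an unsubstituted phenyl, a fluorobenzyl or a longer chain such as phenethyl would read at this position.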